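The source may report more compounds than this note shows. Statements on the series, on what has been measured and on what is new or still open speak of the compounds shown alone.

- Compound 1 `Cc1cc(Nc2nn(-c3ccc(F)cc3)c(=O)c3ccccc23)n[nH]1` - 1600 nM
- Compound 2 `Cc1cc(Nc2nn(Cc3ccc(S(C)(=O)=O)cc3)c(=O)c3ccccc23)n[nH]1` - 4500 nM
- Compound 3 `Cc1ccc(-n2nc(Nc3cc[nH]n3)c3ccccc3c2=O)cc1` - "not determined" (no result reported)

Going by the values given here, in a functional assay on MCF7 cells (Homo sapiens) for cytotoxicity (a lower number here means a stronger inhibitor, a higher number a weaker inhibitor), compound 1 gives 1600 nM and holds the lower of the only two numbers available. Compound 2 gives 4500 nM and this gap lies beyond the usual scatter of repeated measurements. Compound 3 has no number to compare.

The next compound to be tested is compound 4 `Cc1cc(Nc2nn(CC(C)C)c(=O)c3ccccc23)n[nH]1` which has isobutyl in place of 4-fluorophenyl on an aromatic nitrogen and is otherwise the same as compound 1. Among the compounds with values here, no two measured compounds differ in one place only, so the data offer no direct guide to this swap. With so little to go on, only a small change can reasonably be forecast in this assay and a slightly higher number, meaning a slightly weaker compound, seems the safer guess. The estimated step of a 1.8-fold higher number from compound 1 to compound 4 (0.24 log units; within the scatter) is expected to stay within the scatter. Compound 4 is expected to give about 2800 nM with an estimated range from 1000 nM to 8000 nM.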

Compound 4, half-maximal inhibitory concentration: 4200 nM
For compound 4 the middle estimate is 1.5-fold (0.18 log units) below the measured one; low and high end bracket the measured number.
By their numbers in this assay, from the lowest: compound 1; then compounds 4 and 2 (each within the scatter of the next).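

Going by these compounds alone, this gives the first direct reading at this position, the aromatic nitrogen of the shared core. In this assay, putting isobutyl in place of 4-fluorophenyl gives a 2.6-fold higher number from compound 1 to compound 4 (0.42 log units; beyond the scatter), so the group here does affect the result, although the step is modest and a chain with no ring still leaves a compound with a measurable number. No measured property is available to explain this step.

The swap removes the ring and the fluorine together and also changes the size of the group, so this single step cannot show which of these differences matters. It also leaves open how an unsubstituted phenyl, a longer chain or a chain ending in an amine would compare at this position.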